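The compounds below may be only part of what the source reports. "The series", "measured", "known", "first", "only" and "open" are said of these compounds alone.

Measured compounds:
compound 1 `Cn1c(-c2cccc3ccccc23)nnc1[S+](C)[O-]` — > 200 mg/kg
compound 2 `Cn1c(-c2cccc3ccccc23)nnc1S(C)(=O)=O` — > 200 mg/kg
compound 3 `COc1ccc(-c2nnc([S+](C)[O-])n2C)cc1` — > 100 mg/kg

In a functional assay on the whole organism for antagonist activity, with Mus musculus as the target (on this read-out lower numbers stand for an effect already at smaller amounts and higher numbers for an effect only at larger amounts of compound), compound 1 gives only a limit, > 200 mg/kg. Compound 2 likewise gives only a limit in this assay, > 200 mg/kg. Compound 3 gives only a limit in this assay, > 100 mg/kg. Every value in the set is thus a limit and not a number; two sit at the limit of > 200 mg/kg in this assay, at which 2 of the 3 values shown sit, and one at the limit of > 100 mg/kg in this assay, at which 1 of the 3 values shown sits.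

The change from compound 1 to compound 2 is a group of 4 heavy atoms (1 carbon, 2 oxygen, 1 sulfur; no ring) in place of a group of 3 heavy atoms (1 carbon, 1 oxygen, 1 sulfur; no ring), on an aromatic carbon. The step that the two limits leave unreadable from compound 1 to compound 2 cannot be read because both ends are limits. How the core of compound 3 differs from the core of compound 1 is not broken down here.

Compound 4 `COc1ccc(-c2nnc(S(C)(=O)=O)n2C)cc1` carries the same kind of change on the core of compound 3: a group of 4 heavy atoms (1 carbon, 2 oxygen, 1 sulfur; no ring) in place of a group of 3 heavy atoms (1 carbon, 1 oxygen, 1 sulfur; no ring), on an aromatic carbon. The surroundings of the change differ between the two pairs only in the group borne by the ring atom two ring bonds from the changed carbon, as the two counted differences show.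

Expectation for compound 4 rests on compound 3 with its value > 100 mg/kg and on the unreadable step from compound 1 to compound 2, which gives no sign that the change moves the read-out out of the limit region. The step from compound 3 to compound 4 is estimated as a step that the limit leaves unreadable from compound 3 to compound 4. Compound 4 is expected at about 150 mg/kg, with a range from 50 mg/kg to 400 mg/kg, and most likely it will again return only a limit.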

Compound 4, dose for half-maximal effect: > 200 mg/kg
Compound 4: no number, only a limit (the forecaster's own chance of this, stated with the estimate: 85%); at least 1.3-fold (0.12 log units) between middle value and limit.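

In this assay compound 3 gives only a limit, > 100 mg/kg. Compound 4 likewise gives only a limit, > 200 mg/kg, so no step can be read between compound 3 and compound 4. The compounds shown leave open whether methylsulfonyl in place of the group it replaces moves the read-out at all, on the core of compound 3 or on the core of compound 1.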